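Compound 4 and the limit of compound 1

A few compounds are considered here, and "the series" means these few. Any claim that something is new, unique, unknown or untested is made for them only; others in the source may bear on it.

In a functional assay on HepG2 cells (Homo sapiens) for cytotoxicity, read by MTT assay, with a stated time of 72 h (a lower number here means a stronger inhibitor, a higher number a weaker inhibitor), three compounds have been measured so far.
- Compound 1 (`Cc1c(C)c2c(c(C)c1OC(=O)CCC(=O)O)CCC(C)(C(=O)NC1CC(C)(C)N([O])C(C)(C)C1)O2`) gives > 300000 nM (a limit)
- Compound 2 (`Cc1c(C)c2c(c(C)c1O)CCC(C)(C(=O)NC1CC(C)(C)N([O])C(C)(C)C1)O2`) gives 54000 nM (a number)
- Compound 3 (`Cc1c(C)c2c(c(C)c1OC(=O)CCC(=O)NC1CC(C)(C)N([O])C1(C)C)CC[C@@](C)(CCC[C@H](C)CCC[C@H](C)CCCC(C)C)O2`) gives > 300000 nM (a limit)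

Compound 1 gives only a limit and no number (the limit of > 300000 nM in this assay, at which 2 of the 3 values shown sit). The next structure is compound 4 (`Cc1c(C)c2c(c(C)c1OC(=O)CCC(=O)O)CCC(C)(C(=O)O)O2`), and the change is one oxygen atom in place of a group of 12 heavy atoms (9 carbon, 2 nitrogen, 1 oxygen; one six-membered non-aromatic ring with 1 hetero atom), on a carbonyl carbon, so hydroxy now sits on that carbonyl carbon. Among the compounds with values here, the one measured step, an at least 5.5-fold lower number from compound 1 to compound 2 (0.74 log units; beyond the scatter), concerns another part of the molecule and bears on this change only indirectly. In this assay no step beyond the scatter is therefore expected, in either direction, and the expected step is a step that the limit leaves unreadable from compound 1 to compound 4. For compound 4 the estimated value is 350000 nM, with an expected range from 150000 nM to 800000 nM, quite possibly reported as a limit again.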

Compound 4, half-maximal inhibitory concentration: 242000 nM
Estimate against measurement, compound 4: 1.4-fold (0.16 log units) above; the range from low to high includes it.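

In this assay the exchange of the ring-bearing group for hydroxy on the carbonyl carbon gives an at least 1.2-fold lower number from compound 1 to compound 4 (0.09 log units; that floor lies within the scatter) and so shows no change beyond the scatter, though it rules none out. Within the data shown here, compound 4 keeps the (2-carboxyethyl)carbonyl group on oxygen and still gives a number, which the earlier compounds carrying that group did not. The step remains only a floor because compound 1 gives a limit: the limit of > 300000 nM in this assay, at which 2 of the 4 values shown sit.

The compounds shown leave open how a methyl ester or a simple primary amide on that carbonyl carbon would read.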